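The source may hold more compounds than are shown below. What is called first, only, known or untested is meant among the compounds shown, and "the series" means these compounds.

Measured so far in a toxicity assay on WI-38 cells (Homo sapiens) for cytotoxicity, read by MTT assay, with a stated time of 48 h; a higher number here means a weaker inhibitor, a lower number a stronger inhibitor:
Compound 1 `O=C(/C=C/c1ccc2c(c1)B(O)OC2)c1ccc(F)cc1`: 7600 nM
Compound 2 `O=C(/C=C/c1ccc2c(c1)B(O)OC2)c1ccc(I)cc1`: > 100000 nM, a limit of the assay

Compound 2 stands at the limit of > 100000 nM in this assay, at which 1 of the 2 values shown sits; in this assay compound 2 gave no number, only a limit. Within the data shown here, the single measured step, an at least 13-fold higher number from compound 1 to compound 2 (1.11 log units; beyond the scatter), is large, but because compound 2 sits on the limit of > 100000 nM in this assay, at which 1 of the 2 values shown sits, the true size of that step is unknown.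

The next compound, compound 3 `CCc1ccc(C(=O)/C=C/c2ccc3c(c2)B(O)OC3)cc1`, differs from compound 2 by ethyl in place of iodo on an aromatic carbon. Among the measured compounds shown here, no measured step swaps iodo for ethyl, so the fluoro-to-iodo step is the only guide, and it carried the number from a plain value to the limit. Where ethyl falls relative to those two substituents is not shown by anything here, so compound 3 is expected to lie somewhere between compound 1 and the limit. Compound 3 is therefore estimated at 40000 nM in this assay, within 8000 nM to 150000 nM. The expected step is an at least 2.5-fold lower number from compound 2 to compound 3 (0.39 log units; beyond the scatter), with considerable uncertainty and a real chance that this assay again reports only a limit.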

Compound 3, half-maximal inhibitory concentration: 20600 nM
The estimate for compound 3 lay 1.9-fold (0.29 log units) above the measured number, and the stated range covers the measured number.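

In this assay, this aromatic carbon, para to a large group, now carries a third substituent with a plain value, and ethyl in place of fluoro gives a 2.7-fold higher number from compound 1 to compound 3 (0.43 log units; beyond the scatter). Ethyl in place of iodo gives an at least 4.8-fold lower number from compound 2 to compound 3 (0.68 log units; beyond the scatter), so moving away from fluoro at this position does not by itself carry the number to the limit, and compound 3 lies between the other two compounds on the values printed. The second step remains a minimum, since compound 2 gave a limit and no number: the limit of > 100000 nM in this assay, at which 1 of the 3 values shown sits.

With only fluoro, ethyl and iodo at this position, the compounds shown leave open how an amine, a carboxylic acid or a longer chain such as butyl would read in this assay. They also leave open whether chloro or bromo would fall nearer to compound 1 or to compound 2, and so whether the sharp change seen with iodo belongs to the halogens as a series or to iodo alone.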